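Quinolone ester series: cytotoxicity limits and one untested analogue

The compounds below may be only part of what the source reports. "The series", "measured", "known", "first", "only" and "open" are said of these compounds alone.

Measured so far in an ADME assay on HepG2 cells (Homo sapiens) for cytotoxicity, read by luminescence, with a stated time of 72 h; on this read-out lower numbers stand for an effect already at smaller amounts and higher numbers for an effect only at larger amounts of compound:
Compound 1, `CCOC(=O)c1c(-c2cccc(-c3ccccc3)c2)[nH]c2cc(OC)c(Cl)cc2c1=O`, gives > 21500 nM, which is a limit of the assay and not a number.
Compound 2, `CCOC(=O)c1c(-c2cccc(OC)c2)[nH]c2cc(OC)c(Cl)cc2c1=O`, gives > 21500 nM, again a limit rather than a number.
Compound 3, `CCOC(=O)c1c(-c2cccc(-c3ccccc3)c2)[nH]c2cc(OC)c(F)cc2c1=O`, gives > 21500 nM, also a limit rather than a number.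

All three values therefore sit at one and the same point, (the limit of > 21500 nM in this assay, at which 3 of the 3 values shown sit). Compound 2 differs from compound 1 by methoxy in place of phenyl on an aromatic carbon; the corresponding step in this assay is a step that the two limits leave unreadable from compound 1 to compound 2. Compound 3 differs from compound 1 in the core, by fluoro in place of chloro on an aromatic carbon; that step is a step that the two limits leave unreadable from compound 1 to compound 3. Neither step can be read, so nothing about the direction of either change follows from the data.

Compound 4, `CCOC(=O)c1c(-c2cccc(OC)c2)[nH]c2cc(OC)c(F)cc2c1=O`, has not yet been measured. It differs from compound 3 by methoxy in place of phenyl on an aromatic carbon. The place of the change is described in the same words as for the change from compound 1 to compound 2, so this is the same change carried onto the core of compound 3. Within the data shown here, for compound 4 the step expected in this assay is a step that the limit leaves unreadable from compound 3 to compound 4, which rests on compound 1 and compound 2 because a step that the two limits leave unreadable from compound 1 to compound 2 is the matching step and because the limit of > 21500 nM in this assay, at which 3 of the 3 values shown sit, holds for every value so far. Compound 4 is estimated at 30000 nM, with an expected range from 15000 nM to 100000 nM, and the assay is expected most likely to report only a limit again.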

Compound 4, half-maximal effective concentration: > 21500 nM
Compound 4: a limit, no number (the forecaster's own chance of this, stated with the estimate: 85%); the middle value is on the limit's open side.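

Among these compounds, compound 4 also returns a limit and not a number in this assay, so its steps from compound 3 and from compound 2 cannot be read and no new step follows: the limit of > 21500 nM in this assay, at which 4 of the 4 values shown sit.

The compounds shown leave open at what concentration, if any, each of the four compounds reaches a half-maximal effect, and whether either methoxy in place of phenyl or fluoro in place of chloro shifts that concentration in either direction.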